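The compounds below may be only part of what the source reports. "The series", "measured", "known", "first", "only" and "open" are said of these compounds alone.

Measured in an assay on COS-7 cells for inhibition of patatin-like phospholipase domain-containing protein 2 (Mus musculus), tested at 200 uM; a higher number here means more inhibition at the concentration tested (going by the name of the read-out), a lower number less inhibition:

Compound 1, `CCNS(=O)(=O)c1cccc(-c2ccc(OCC)cc2)c1`: 46%
Compound 2, `CCOc1ccc(-c2cccc(S(=O)(=O)NC)c2)cc1`: 47%
Compound 3, `COC(=O)Nc1cccc(-c2ccc(N(C)C)cc2)c1`: 95%

Compound 1 and compound 2 share one core, while compound 3 is built on a different one; the difference between the two cores is not broken down here. Compound 3 stands clearly highest of the three. The gap between compound 3 and compound 2 is beyond the scatter of this kind of measurement. The gap between compound 3 and compound 1 is beyond it as well. Compound 2 and compound 1, on the other hand, differ by a single small change, (methyl in place of hydrogen on a saturated chain carbon bound to a sulfonamide nitrogen). That change made a number 1 percentage points lower from compound 2 to compound 1 (within the scatter), so the two compounds cannot be ordered against each other.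

Compound 4, `CCOC(=O)Nc1cccc(-c2ccc(N(C)C)cc2)c1`, has not yet been measured in this assay. It is derived from compound 3 by methyl in place of hydrogen on a saturated chain carbon bound to an oxygen next to a carbonyl group. This is the same kind of change as between compound 2 and compound 1, but not the same: there the added carbon sits on a saturated chain carbon bound to a sulfonamide nitrogen, here on a saturated chain carbon bound to an oxygen next to a carbonyl group.

Among the measured compounds shown here, on that basis compound 4 is expected to move by about a number 5 percentage points lower from compound 3 to compound 4 (within the scatter), because the only measured example of this kind of change gave a number 1 percentage points lower from compound 2 to compound 1 (within the scatter) and because compound 3 already gives 95%, leaving little room upward. The estimate for compound 4 is 90%, with a range from 72% to 99%.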

Compound 4, a percentage reported as inhibition, at one concentration (the size of the read-out at that concentration, not a potency): 93%
Estimate against measurement, compound 4: 3 percentage points below; measured number inside the range.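

Adding one carbon, which turns the methoxycarbonyl group of compound 3 into the ethoxycarbonyl group of compound 4, gave a number 2 percentage points lower from compound 3 to compound 4 (within the scatter) in this assay, so these two compounds cannot be ordered against each other. Set beside the earlier example of the same kind of change, on a different core and at a different place, the new step reads the same: the same change on two cores in this assay, a number 1 percentage points lower (within the scatter) from compound 2 to compound 1 and a number 2 percentage points lower (within the scatter) from compound 3 to compound 4, 1 percentage points apart, within the scatter of two such steps

This shows that, in these two pairs, going from a methyl to an ethyl group left the read-out within the scatter, whether the starting level was near the middle of the scale or close to its top; it does not establish a rule for other cores or other places on these molecules, and it says nothing about why the read-out stayed put, since two pairs are a small basis and each gives only a single-concentration reading.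

Going by these compounds, whether the pattern would hold for a longer chain such as propyl or butyl, or for a branched isopropyl group, remains open. Also open, on these data alone, is what an amine or a carboxylic acid at the same place would do on either core.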